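Swapping the Benzyl Ring on the Core: Compound 4

This account rests on a few compounds, and the source may have more. Where it says the series, first, only, none or still open, it means among the compounds named here.

Compound 1, `O=C(OC1C=CC(n2ccc(=O)[nH]c2=O)C1)c1ccccc1`: in an ADME assay on CCRF-CEM cells (Homo sapiens) for cytotoxicity, with a stated time of 3 days (a lower number here means that less compound is tolerated, a higher number that more compound is tolerated), compound 1 reaches only a limit, > 250000 nM.
Compound 2, `Cc1cc(C)cc(Cn2c(=O)ccn(C3C=CC(OC(=O)c4ccccc4)C3)c2=O)c1`: in this assay compound 2 gives 40000 nM.
Compound 3, `Cc1ccc(Cn2c(=O)ccn(C3C=CC(OC(=O)c4ccccc4)C3)c2=O)c(C)c1`: in this assay compound 3 gives 31000 nM.

Compound 3 holds the lower of the two actual numbers, but compound 2 sits so close that the two cannot be told apart: a 1.3-fold lower number from compound 2 to compound 3 (0.11 log units; within the scatter). For compound 1 only a limit is recorded, (the limit of > 250000 nM in this assay, at which 1 of the 3 values shown sits).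

Compound 4, `O=C(OC1C=CC(n2ccc(=O)n(Cc3cc(F)cc(F)c3)c2=O)C1)c1ccccc1`, is built from compound 3 by one change: 3,5-difluorophenyl in place of 2,4-dimethylphenyl on a saturated chain carbon bound to an aromatic nitrogen. Two measured steps show that putting a benzyl group on the aromatic nitrogen of the shared core brings the number down, an at least 6.2-fold lower number from compound 1 to compound 2 (0.79 log units; beyond the scatter) and an at least 8.0-fold lower number from compound 1 to compound 3 (0.90 log units; beyond the scatter). Among the measured compounds shown here, the only measured step that, like this one, alters the ring on that benzyl group is a 1.3-fold lower number from compound 2 to compound 3 (0.11 log units; within the scatter), which stays within the scatter. No fluorine-bearing benzyl has been measured, so the two fluorines remain an open question.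

The expected step is therefore small, a 1.1-fold higher number from compound 3 to compound 4 (0.05 log units; within the scatter). Compound 4 is estimated at 35000 nM, within 12000 nM to 120000 nM.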

Compound 4, half-maximal cytotoxic concentration: 32000 nM
Beside the measured number, compound 4's estimate is 1.1-fold (0.04 log units) above it; the measured number falls inside the stated range.
By their numbers in this assay, from the lowest: compounds 3, 4 and 2 (each within the scatter of the next). At a limit, above all of these: compound 1.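

Fluorine on the benzyl ring is new here, and in this assay it makes no readable difference: replacing 2,4-dimethylphenyl with 3,5-difluorophenyl gives a 1.0-fold higher number from compound 3 to compound 4 (0.01 log units; within the scatter). Changing only the two methyl groups to fluorines reads the same way, with a 1.3-fold lower number from compound 2 to compound 4 (0.10 log units; within the scatter), so at this place all three benzyl groups shown are indistinguishable. The 3,5-difluorobenzyl group also joins the other two in the step from hydrogen on the aromatic nitrogen, an at least 7.8-fold lower number from compound 1 to compound 4 (0.89 log units; beyond the scatter), although the size of that step is only a bound set by compound 1: the limit of > 250000 nM in this assay, at which 1 of the 4 values shown sits.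

Every benzyl ring shown carries two methyl groups or two fluorines, so a ring bearing an amine or a carboxylic acid, or a longer chain to the ring, remains open. Also open, from the compounds shown here alone, is how an amide in place of the benzoyl ester would read.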